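Extending the Acyl Chain on a Guanidine Amide

The source may report more compounds than this note shows. Statements on the series, on what has been measured and on what is new or still open speak of the compounds shown alone.

Measured so far:
compound 1, `CC(C)=CCC/C(C)=C/CC/C(C)=C/C(=O)NC(=N)N`: 13700 nM
compound 2, `CC(C)=CCC/C(C)=C/CC/C(C)=C/C(=O)NC(=N)NC(=O)C=C(C)C`: 23400 nM

Among the compounds with values here, in a functional assay on A549 cells (Homo sapiens) for inhibition, read by MTT assay, with a stated time of 72 h (on this read-out higher numbers stand for weaker inhibition of growth and lower numbers for stronger inhibition of growth), compound 2 gives the higher of the two numbers, and the only measured step, a 1.7-fold higher number from compound 1 to compound 2 (0.23 log units; within the scatter), stays within the scatter. Compound 3, `CC(C)=CCC/C(C)=C/CC/C(C)=C/C(=O)NC(=N)NC(=O)/C=C(\C)CC/C=C(\C)CCC=C(C)C`, differs from compound 2 by 3,7-dimethylocta-2,6-dien-1-yl in place of hydrogen on a saturated chain carbon bound to a double-bonded chain carbon. Within the data shown here, no measured step touches that position, so the single step at hand offers no direct guide; it only shows that one change on this scaffold left the read-out essentially unmoved. Compound 3 is therefore expected to show a 1.2-fold lower number from compound 2 to compound 3 (0.07 log units; within the scatter), a step not clearly beyond the scatter. Compound 3 is estimated at 20000 nM, within 7000 nM to 60000 nM.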

Compound 3, concentration for 50% growth inhibition: 18500 nM
For compound 3 the middle estimate is 1.1-fold (0.03 log units) above the measured one; measured number inside the range.
By their numbers in this assay, from the lowest: compounds 1, 3 and 2 (each within the scatter of the next).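

In this assay the 3,7-dimethylocta-2,6-dien-1-yl group, placed on a saturated chain carbon bound to a double-bonded chain carbon, gives a 1.3-fold lower number from compound 2 to compound 3 (0.10 log units; within the scatter) and so leaves the read-out without a shift beyond the scatter. The earlier step showed this only for the smaller (2-methylprop-1-en-1-yl)carbonyl group on an amine nitrogen, whereas this step shows it for a group of 10 heavy atoms at a different place. No evidence on the reason for this result is at hand. As far as these compounds go, whether an amine or a carboxylic acid at this position would move the number beyond the scatter remains open.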